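The source may report more compounds than this note shows. Statements on the series, on what has been measured and on what is new or still open speak of the compounds shown alone.

Compound 1 `COC(=O)C1=C(C)N=C(C)/C(=C(/O)OC)C1c1cccc(N/C(=N/CCNC2CCN(c3ccccc3OC(F)(F)F)CC2)NC#N)c1` and compound 2 `COC(=O)C1=C(C)N=C(C)/C(=C(/O)OC)C1c1cccc(N/C(=N/CCNC2CCN(c3ccccc3O)CC2)NC#N)c1` share one core and differ only in hydrogen in place of trifluoromethyl on an oxygen on an aromatic ring. In an assay on SK-N-MC cells for inhibition of Neuropeptide Y receptor type 1 (Homo sapiens) (a lower number here means a stronger inhibitor, a higher number a weaker inhibitor), compound 1 gives 28 nM, while compound 2 gives 5 nM, so the change produced a 5.6-fold lower number from compound 1 to compound 2 (0.75 log units; beyond the scatter). Compound 3 `COC(=O)C1=C(C)N=C(C)/C(=C(/O)OC)C1c1cccc(NC(=O)NCCNC2CCN(c3ccccc3OC(F)(F)F)CC2)c1` is built on a different core, and the difference between the two cores is not broken down here. In this assay compound 3 gives 25 nM, a number close to that of compound 1. Compound 4 `COC(=O)C1=C(C)N=C(C)/C(=C(/O)OC)C1c1cccc(NC(=O)NCCNC2CCN(c3ccccc3O)CC2)c1` arises from compound 3 by the same change, (hydrogen in place of trifluoromethyl on an oxygen on an aromatic ring), made at the same place. The earlier step of this change was a 5.6-fold lower number from compound 1 to compound 2 (0.75 log units; beyond the scatter). The same change on compound 3 is expected to give a 5.0-fold lower number from compound 3 to compound 4 (0.70 log units; beyond the scatter). Compound 4 is therefore expected to reach about 5 nM, with a likely range from 2 nM to 12 nM.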

Compound 4, half-maximal inhibitory concentration: 6 nM
For compound 4 the middle estimate is 1.2-fold (0.08 log units) below the measured one, within the range that was stated.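

In this assay, putting hydrogen in place of trifluoromethyl on the oxygen gave a 4.2-fold lower number from compound 3 to compound 4 (0.62 log units; beyond the scatter) and the two steps agree: the same change on two cores in this assay, a 5.6-fold lower number (0.75 log units; beyond the scatter) from compound 1 to compound 2 and a 4.2-fold lower number (0.62 log units; beyond the scatter) from compound 3 to compound 4, 1.3-fold (0.13 log units) apart, within the scatter of two such steps. In this series, then, the change carried over from the core of compound 1 to the core of compound 3 with much the same size. Going by these compounds alone, that rests on only two pairs, and it does not show why the number falls or whether the step would hold on any further core or in any other assay.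

The compounds shown leave open how other groups on that oxygen, such as methyl or a longer chain like ethyl, would compare with hydrogen and trifluoromethyl. They also leave open what an amine or a carboxylic acid would do in place of the hydroxy group.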